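The source may report more compounds than this note shows. Statements on the series, on what has been measured and on what is new or still open speak of the compounds shown alone.

Measured compounds in the series so far:

compound 1, `O=C1COc2ccc(-c3cnc(Cl)c(NS(=O)(=O)c4ccc(F)cc4)c3)cc2N1C1CCCCC1`: > 40000 nM
compound 2, `Cc1ccc(N2C(=O)COc3ccc(-c4cnc(Cl)c(NS(=O)(=O)c5ccc(F)cc5)c4)cc32)cc1`: 39600 nM
compound 3, `O=C1COc2ccc(-c3cccc(NS(=O)(=O)c4ccc(F)cc4)c3)cc2N1C1CCCCC1`: 35900 nM

All three were run in a functional assay on HepG2 cells (Homo sapiens) for antiproliferative activity, read by MTT assay, with a stated time of 72 h; a lower number here means a stronger inhibitor, a higher number a weaker inhibitor. For compound 1 the entry > 40000 nM is a limit of the assay, not a number, and it marks (the limit of > 40000 nM in this assay, at which 1 of the 3 values shown sits). Compound 2 gives 39600 nM. Compound 3 gives 35900 nM, and its gap to compound 2 lies within the scatter, so no order between the two is claimed.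

Compound 1 and compound 2 differ in one place: 4-methylphenyl in place of cyclohexyl on an amide-type nitrogen in a ring. The step it made, a number no higher from compound 1 to compound 2 (the limit leaves the size open), cannot be sized, since compound 1 stands only at a limit. The core of compound 3 differs from the core of compound 1 in more than one place; that difference is not broken down here.

Compound 4, `Cc1ccc(N2C(=O)COc3ccc(-c4cccc(NS(=O)(=O)c5ccc(F)cc5)c4)cc32)cc1`, is not yet measured. It stands to compound 3 as compound 2 stands to compound 1: 4-methylphenyl in place of cyclohexyl on an amide-type nitrogen in a ring. The place is the same word for word in both pairs, so this is the same change, now made on the core of compound 3.

With the earlier step unsized, the expectation for compound 4 rests on compound 3 sitting at 35900 nM and on compound 2, carrying the same 4-methylphenyl on the same nitrogen, sitting at 39600 nM. The step expected is a 1.0-fold higher number from compound 3 to compound 4 (0.00 log units; within the scatter), essentially flat within the scatter. The estimate for compound 4 in this assay is therefore 36000 nM, with a range from 15000 nM to 80000 nM, and a real chance that only a limit is reported.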

Compound 4, half-maximal inhibitory concentration: > 40000 nM
Compound 4: only a limit was reported; the forecaster's own chance of this, stated with the estimate: 30%; at least 1.1-fold (0.04 log units) between middle value and limit.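

Carried to the second core, 4-methylphenyl in place of cyclohexyl on the amide-type nitrogen in a ring gives an at least 1.1-fold higher number from compound 3 to compound 4 (0.04 log units; that floor lies within the scatter) in this assay. Compound 4 gives > 40000 nM, which is a limit of the assay and not a number. The change produces no readable gain on this core, but neither step has a fixed size, so the notes cannot say whether it behaves alike on both cores or differently, and no transfer of the change from one core to the other is shown: the same change on two cores in this assay, a number no higher (the limit leaves the size open) from compound 1 to compound 2 and an at least 1.1-fold higher number (0.04 log units; that floor lies within the scatter) from compound 3 to compound 4; the limit leaves it open whether they differ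

Going by these compounds, only cyclohexyl and 4-methylphenyl appear on this nitrogen, and the series sits largely at the top of the readable range: the limit of > 40000 nM in this assay, at which 2 of the 4 values shown sit. Still open is whether a different group on that nitrogen, such as a chain carrying an amine or a carboxylic acid, would bring a value clearly under the limit in this assay and so give a step that can be sized and compared across the two cores.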